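The compounds below may be only part of what the source reports. "The series", "measured", "known", "first", "only" and "open" are said of these compounds alone.

Compound 1 `NCC(=O)NCc1nnc(-c2ccccc2)o1` gives 283 nM
Compound 2 `C[C@@H](N)C(=O)NCc1nnc(-c2ccccc2)o1` gives 230 nM
Compound 3 `COc1ccc(-c2nnc(CNC(=O)[C@@H](C)N)o2)cc1` gives 295 nM

These values come from a functional assay on MDA-MB-231 cells (Homo sapiens) for cytotoxicity, read by MTT assay, with a stated time of 24 h (a lower number here means a stronger inhibitor, a higher number a weaker inhibitor), and lie close together. Compound 1 is within the usual scatter of both compound 2 and compound 3, so no order can be read among the three.

Compound 4 `NCC(=O)NCc1nnc(-c2ccc([N+](=O)[O-])cc2)o1` has not yet been measured. It differs from compound 1 by one change, (nitro in place of hydrogen on an aromatic carbon), which places nitro in place of hydrogen on an aromatic carbon, para to a large group.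

Two measured steps offer guidance. The closer one is methoxy in place of hydrogen on an aromatic carbon (a 1.3-fold higher number from compound 2 to compound 3 (0.11 log units; within the scatter)), which shows a change on an aromatic carbon, though with a different group. The other is methyl in place of hydrogen on a saturated chain carbon (a 1.2-fold lower number from compound 1 to compound 2 (0.09 log units; within the scatter)), a change elsewhere in the molecule. Among the measured compounds shown here, neither step leaves the scatter, but no compound with a nitro group has been measured, so this evidence is thin. No step beyond the scatter is therefore expected in this assay, and no direction can be favoured. The estimate amounts to an expected 1.1-fold lower number from compound 1 to compound 4 (0.05 log units; within the scatter) and no more. For compound 4 the estimated value is 250 nM, with an expected range from 100 nM to 600 nM, kept wide for the untested group.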

Compound 4, half-maximal inhibitory concentration: 276 nM
Compound 4: middle estimate off by 1.1-fold (0.04 log units), on the low side; low and high end bracket the measured number.
By their numbers in this assay, from the lowest: compounds 2, 4, 1 and 3 (each within the scatter of the next).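

In this assay, placing nitro on an aromatic carbon of the six-membered ring, para to a large group, gives a 1.0-fold lower number from compound 1 to compound 4 (0.01 log units; within the scatter) and so leaves the number within the usual scatter, even though this group adds three heavy atoms. Until now, the only change shown on that ring was methoxy, made on compound 2, which carries the methyl on its chain; compound 4 extends the picture to a second, different group, on the side chain of compound 1, and again no step beyond the scatter appears. No measurement here offers a reason why the number stays put in these two cases.

From the compounds shown here alone, whether other groups at this aromatic carbon, such as an amine or a carboxylic acid, would also leave the number within the scatter remains open, as does the effect of a longer chain in place of the short amino-bearing side chain. Every compound shown lies within the scatter of the others. These compounds do not yet reveal any change that clearly moves the number up or down.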